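A few compounds are considered here, and "the series" means these few. Any claim that something is new, unique, unknown or untested is made for them only; others in the source may bear on it.

Measured in a functional assay on NCI-H460 cells (Homo sapiens) for antiproliferative activity, read by sulforhodamine B assay, with a stated time of 72 h; on this read-out lower numbers stand for stronger inhibition and higher numbers for weaker inhibition:

compound 1 `CN(CCNCc1cn(-c2ccccc2Cl)nn1)CCNc1ccnc2cc(Cl)ccc12`: 20000 nM
compound 2 `CN(CCNCc1cn(Cc2ccc(Br)cc2)nn1)CCNc1ccnc2cc(Cl)ccc12`: 12000 nM

Compound 1 stands at the higher of the two numbers, with compound 2 the nearest; the step of a 1.7-fold lower number from compound 1 to compound 2 (0.22 log units; within the scatter) lies within the scatter, so the two compounds cannot be ranked against each other.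

Compound 3 `CN(CCNCc1cn(CCCO)nn1)CCNc1ccnc2cc(Cl)ccc12` keeps the shared core and differs from compound 1 in one place: 3-hydroxypropyl in place of 2-chlorophenyl on an aromatic nitrogen. Among the compounds with values here, no measured step bears directly on this change. Within the data shown here, the only step in hand, a 1.7-fold lower number from compound 1 to compound 2 (0.22 log units; within the scatter), exchanges one aromatic group on that nitrogen for another and was within the scatter, which gives no sign that this position moves the number much. With both measured values weak, no step beyond the scatter is expected; the estimated change is a 1.3-fold higher number from compound 1 to compound 3 (0.10 log units; within the scatter). Compound 3 is therefore expected near 25000 nM, within 9000 nM to 70000 nM.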

Compound 3, half-maximal inhibitory concentration: > 200000 nM
Compound 3 gave a limit, no number; the forecaster's own chance of this, stated with the estimate: 25%; at least 8.0-fold (0.90 log units) between middle value and limit.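

In this assay compound 3 gives a limit of the assay and not a number: the limit of > 200000 nM in this assay, at which 1 of the 3 values shown sits. The position is therefore not silent, as the step between compound 1 and compound 2 left it: the change to 3-hydroxypropyl gives an at least 10-fold higher number from compound 1 to compound 3 (1.00 log units; beyond the scatter), and the comparison with the 4-bromobenzyl compound gives an at least 16-fold higher number from compound 2 to compound 3 (1.22 log units; beyond the scatter). Both steps lie beyond the scatter, and of the three compounds, only compound 3 carries no six-membered aromatic ring on this nitrogen.

Still open, on these data alone, is whether the loss of the ring or the entry of the hydroxyl carries these steps, as the two coincide in compound 3. A plain propyl chain or a cyclohexyl group on the same nitrogen would bear on that question, and neither stands among the compounds shown.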